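Flipping one ring stereocentre on the shared core

The compounds below may be only part of what the source reports. "The series", "measured", "known", "first", "only" and "open" are said of these compounds alone.

Compound 1 `CCS(=O)(=O)N[C@@H]1C=C[C@H](OC(C)=O)[C@@H](COC(C)=O)O1` was tested in a functional assay on HepG2 cells (Homo sapiens) for cytotoxicity, read by MTT assay, with a stated time of 48 h (on this read-out lower numbers stand for stronger inhibition and higher numbers for weaker inhibition), where compound 1 gives 231000000 nM. Compound 2 `CC(=O)OC[C@H]1O[C@H](NS(=O)(=O)c2ccc(C)cc2)C=C[C@@H]1OC(C)=O` gives 157000000 nM in this assay, and the step of a 1.5-fold lower number from compound 1 to compound 2 (0.17 log units; within the scatter) changes only the group on the sulfonyl sulfur. Compound 3 `CCS(=O)(=O)N[C@@H]1C=C[C@@H](OC(C)=O)[C@@H](COC(C)=O)O1` keeps every atom and bond of compound 1; (the two compounds have the same atoms and bonds and differ only in configuration as drawn: 1 of 3 stereo elements differ; a stereocentre at a saturated ring carbon is drawn S in compound 1 and R in compound 3). For the measured compounds named here, no measured step involves a change of configuration, so the data give no guide to how such a flip moves the number. The expected step of no change at the digits printed from compound 1 to compound 3 (within the scatter) is therefore none beyond the scatter. Compound 3 is estimated at 231000000 nM, within 80000000 nM to 700000000 nM.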

Compound 3, half-maximal inhibitory concentration: 192000000 nM
Estimate against measurement, compound 3: 1.2-fold (0.08 log units) above; the measured number falls inside the stated range.
By their numbers in this assay, from the lowest: compounds 2, 3 and 1 (each within the scatter of the next).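

Turning the stereocentre at this saturated ring carbon from S to R gives, in this assay, a 1.2-fold lower number from compound 1 to compound 3 (0.08 log units; within the scatter). So on this read-out, configuration at this carbon does not separate the pair, a point the change on the sulfonyl sulfur could not address. Only that one stereocentre can account for this small step: the fact that compounds 1 and 3 differ only in the configuration as drawn

As far as these compounds go, whether the flip would also leave the number within the scatter with 4-methylphenyl on the sulfonyl sulfur remains open. So does the effect of a free hydroxyl or an amine at that ring carbon.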